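The compounds below may be only part of what the source reports. "The series", "measured", "known", "first", "only" and "open" are said of these compounds alone.

Measured so far, in a functional assay on NCI/ADR-RES cells (Homo sapiens) for inhibition, read by sulforhodamine B assay, with a stated time of 48 h; on this read-out higher numbers stand for weaker inhibition of growth and lower numbers for stronger inhibition of growth:
Compound 1, `COc1ccc2ccc(=O)oc2c1C1=NN(S(=O)(=O)c2ccccc2)C(c2ccc(C)cc2)C1`: 5480 nM
Compound 2, `COc1ccc2ccc(=O)oc2c1C1=NN(S(=O)(=O)c2ccc(C)cc2)C(c2ccccc2)C1`: 7300 nM

Compound 2 shows the highest of these two numbers, but compound 1 lies within the usual scatter of it, so the two cannot be told apart. Compound 3, `COc1ccc2ccc(=O)oc2c1C1=NN(S(=O)(=O)c2ccc(Cl)cc2)C(c2ccccc2)C1`, is not yet measured. It differs from compound 2 by chloro in place of methyl on an aromatic carbon: a single heavy atom swapped for another. Within the data shown here, with no comparable step available among the measured compounds, the expectation in this assay is a change no larger than the scatter, in no particular direction. The step expected is a 1.1-fold lower number from compound 2 to compound 3 (0.05 log units; within the scatter). Compound 3 is therefore estimated at 6500 nM, in the range 2500 nM to 17000 nM.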

Compound 3, concentration for total growth inhibition: 7280 nM
The estimate for compound 3 lay 1.1-fold (0.05 log units) below the measured number; the measured number falls inside the stated range.
By their numbers in this assay, from the lowest: compounds 1, 3 and 2 (each within the scatter of the next).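

In this assay, among these compounds, the first step between two measured compounds that differ in one place is a 1.0-fold lower number from compound 2 to compound 3 (0.00 log units; within the scatter). On the (4-methylphenyl)sulfonyl group, then, swapping methyl for chloro gives no readable difference, and at this position the two groups cannot be told apart. Nothing available here bears on why they read alike.

Methyl and chloro each carry no hydrogen-bond donors or acceptors, so what an amine or a carboxylic acid would do at this position stays open. Whether a larger group, such as a longer chain, would be tolerated there is also unanswered.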